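Swapping Ethoxycarbonyl for Methyl on a Carbonyl Carbon

The compounds below may be only part of what the source reports. "The series", "measured", "known", "first", "only" and "open" are said of these compounds alone.

Compounds measured in a functional assay on HUVEC cells (Homo sapiens) for inhibition; on this read-out higher numbers stand for weaker inhibition and lower numbers for stronger inhibition:
- compound 1 `COc1cc(/C=C/C(=O)c2cccc(NC(=O)c3c(Cl)cccc3Cl)c2)ccc1O`: 0.46 ug/mL
- compound 2 `COc1cc(/C=C/C(=O)c2cccc(NC(=O)c3cccs3)c2)ccc1O`: 0.38 ug/mL
- compound 3 `CCOC(=O)C(=O)Nc1cccc(C(=O)/C=C/c2ccc(O)c(OC)c2)c1`: 13.3 ug/mL

Compound 3 stands highest of the three on this assay, which makes it the weakest inhibitor so far. Compound 1 and compound 2 lie close together, with a 1.2-fold lower number from compound 1 to compound 2 (0.08 log units; within the scatter).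

The next compound to be tested is compound 4 `COc1cc(/C=C/C(=O)c2cccc(NC(C)=O)c2)ccc1O`, which carries methyl in place of ethoxycarbonyl on a carbonyl carbon. The same difference can be read as ((ethoxycarbonyl)carbonyl)amino to acetamido.

For the measured compounds named here, two measured steps touch this position, and both involve ethoxycarbonyl. One is a 29-fold higher number from compound 1 to compound 3 (1.46 log units; beyond the scatter), and the other is a 35-fold higher number from compound 2 to compound 3 (1.54 log units; beyond the scatter). Both are large and nearly equal in size, even though 2,6-dichlorophenyl and thiophen-2-yl are different groups. Going by the values given here, no measured compound has methyl at this place, so these steps only suggest a direction. Removing ethoxycarbonyl is expected to lower the number, though perhaps not as far as either of those steps. The expected change is a 6.7-fold lower number from compound 3 to compound 4 (0.82 log units; beyond the scatter). Compound 4 is estimated at 2 ug/mL, with an expected range from 0.4 ug/mL to 9 ug/mL.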

Compound 4, half-maximal inhibitory concentration: 7.06 ug/mL
Compound 4: middle estimate off by 3.5-fold (0.55 log units), on the low side, and the stated range covers the measured number.
By their numbers in this assay, from the lowest: compounds 2 and 1 (each within the scatter of the next); then compounds 4 and 3 (each within the scatter of the next).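

In this assay, putting methyl in place of ethoxycarbonyl on the carbonyl carbon gives a 1.9-fold lower number from compound 3 to compound 4 (0.28 log units; within the scatter), so this position does not separate the small group from the larger ester-bearing one, and the high number of compound 3 cannot be pinned on ethoxycarbonyl alone. Methyl stands just as clearly apart from the two ring groups, with a 19-fold higher number from compound 2 to compound 4 (1.27 log units; beyond the scatter) and a 15-fold higher number from compound 1 to compound 4 (1.19 log units; beyond the scatter), so among these four compounds the two with a ring on this carbonyl carbon, thiophen-2-yl and 2,6-dichlorophenyl, hold the low numbers, the two without a ring hold the high numbers, and no compound shown goes against this split. No supporting measurement is available to explain the split.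

The compounds shown leave open whether any ring at this place would give the low numbers or only an aromatic one, since a cyclohexyl group or an unsubstituted phenyl does not appear among them. They also leave open whether a longer chain, such as butyl, or a chain ending in an amine or a carboxylic acid would stay with compound 3 and compound 4 or move toward the ring compounds.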